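The compounds below may be only part of what the source reports. "The series", "measured", "known", "first", "only" and "open" are said of these compounds alone.

Measured in an assay on cells for antagonist activity at transient receptor potential cation channel subfamily V member 1 (Homo sapiens), read by FLIPR and calcium flux, with a stated time of 6 min; on this read-out lower numbers stand for stronger inhibition and higher numbers for weaker inhibition:
- compound 1 `CC(C(=O)NCc1ccc(C(C)(C)C)nc1N1CCCCCC1)c1ccc(NS(C)(=O)=O)c(F)c1`: 0.9 nM
- compound 2 `CC(C)CCOc1nc(C(C)(C)C)ccc1CNC(=O)C(C)c1ccc(NS(C)(=O)=O)c(F)c1`: 0.8 nM
- compound 3 `CC(C(=O)NCc1ccc(C(C)(C)C)nc1OC1CCCC1)c1ccc(NS(C)(=O)=O)c(F)c1`: 1.5 nM

Compound 3 carries the highest of the three numbers, yet both a 1.7-fold higher number from compound 1 to compound 3 (0.22 log units; within the scatter) and a 1.9-fold higher number from compound 2 to compound 3 (0.27 log units; within the scatter) fall within the usual scatter, so the three compounds cannot be told apart on this read-out. Compound 4 `CC(C(=O)NCc1ccc(C(C)(C)C)nc1OC1CCCCC1)c1ccc(NS(C)(=O)=O)c(F)c1` differs from compound 3 by cyclohexyl in place of cyclopentyl on an oxygen on an aromatic ring. Among the measured compounds shown here, the only measured step at this oxygen is a 1.9-fold higher number from compound 2 to compound 3 (0.27 log units; within the scatter), and that exchange of a chain for a ring stayed within the scatter; swapping one ring size for the next is a smaller structural move than that. No step beyond the scatter is therefore expected in this assay. For compound 4 the expected value is 1.3 nM, with a range from 0.6 nM to 3 nM, which amounts to an estimated 1.2-fold lower number from compound 3 to compound 4 (0.06 log units; within the scatter).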

Compound 4, inhibition constant: 2.5 nM
Estimate against measurement, compound 4: 1.9-fold (0.28 log units) below, within the range that was stated.
By their numbers in this assay, from the lowest: compounds 2, 1, 3 and 4 (each within the scatter of the next, the first and the last beyond it).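

In this assay, moving from the five-membered to the six-membered ring on this oxygen gives a 1.7-fold higher number from compound 3 to compound 4 (0.22 log units; within the scatter), so that change alone cannot be read as a real difference. Even so, the cyclohexyl compound is the first here to separate from other compounds, with a 3.1-fold higher number from compound 2 to compound 4 (0.49 log units; beyond the scatter) and a 2.8-fold higher number from compound 1 to compound 4 (0.44 log units; beyond the scatter), both modest steps. Nothing measured here explains these gaps. Still open, from the compounds shown here alone, is how a seven-membered carbon ring, or a tetrahydropyranyl ring with an oxygen in it, would behave on this oxygen.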